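The source may report more compounds than this note shows. Statements on the series, on what has been measured and on what is new or still open speak of the compounds shown alone.

Compound 1 `COc1cc(C(=O)c2cn(-c3ccccc3)cc2-c2ccc(C)cc2)cc(OC)c1OC`: 280 nM
Compound 2 `COc1cc(C(=O)c2cn(-c3ccccc3)cc2-c2ccc(F)cc2)cc(OC)c1OC`: 78 nM
Compound 3 `COc1cc(C(=O)c2cn(-c3cccc(C)c3)cc2-c2ccccc2)cc(OC)c1OC`: 120 nM

All three were tested in a functional assay on MCF7 cells (Homo sapiens) for inhibition, read by trypan blue exclusion, with a stated time of 3 days; on this read-out higher numbers stand for weaker inhibition and lower numbers for stronger inhibition. Compound 1 and compound 2 differ by one change, (fluoro in place of methyl on an aromatic carbon), and that change gave a 3.6-fold lower number from compound 1 to compound 2 (0.56 log units; beyond the scatter). Compound 3 differs from compound 1 in its core; the difference between the two cores is not broken down here. Compound 4 `COc1cc(C(=O)c2cn(-c3cccc(F)c3)cc2-c2ccccc2)cc(OC)c1OC` is the unmeasured partner of compound 3, differing from it by fluoro in place of methyl on an aromatic carbon. This is the same kind of change as from compound 1 to compound 2, but not the same: in compound 2 the fluoro sits para to a large group, in compound 4 it sits meta to a large group. For compound 4 a somewhat smaller step than the earlier one, a 2.0-fold lower number from compound 3 to compound 4 (0.30 log units; within the scatter), is expected, because the earlier 3.6-fold lower number from compound 1 to compound 2 (0.56 log units; beyond the scatter) was only modest and the place around the change is not identical. Compound 4 is therefore estimated at 60 nM, with a likely range from 25 nM to 150 nM.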

Compound 4, half-maximal inhibitory concentration: 350 nM
Compound 4: the middle estimate sits 5.8-fold (0.77 log units) below what was measured; measured number outside the range, above it.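

In this assay, fluoro in place of methyl on an aromatic carbon gave a 2.9-fold higher number from compound 3 to compound 4 (0.46 log units; beyond the scatter), so the swap that helped on the core of compound 1 did not help here. The two results clearly disagree: the same change on two cores in this assay, a 3.6-fold lower number (0.56 log units; beyond the scatter) from compound 1 to compound 2 and a 2.9-fold higher number (0.46 log units; beyond the scatter) from compound 3 to compound 4, 10-fold (1.02 log units) apart, beyond the scatter of two such steps. Going by these compounds alone, this shows that the effect of this swap cannot simply be carried from one core to another, but with only two pairs, in which the change also sits in different places, it does not show whether the core or the place matters, or why.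

Still open, from the compounds shown here alone, is how a chloro, methoxy or amine group in place of the methyl of the 3-methylphenyl would read in this assay. Going by these compounds, whether further cores would follow compound 1 or compound 3 also remains open.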